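Swapping the side-chain ester for a pyrrolidine amide

The source may hold more compounds than are shown below. What is called first, only, known or untested is meant among the compounds shown, and "the series" means these compounds.

Measured compounds:
- compound 1, `CC(=O)Cn1cc(CNC(=O)c2cnc(Nc3ccc(C#N)cc3)cc2Oc2c(C)cc(C)cc2C)nn1`: 19400 nM
- compound 2, `CCOC(=O)CCn1cc(CNC(=O)c2cnc(Nc3ccc(C#N)cc3)cc2Oc2c(C)cc(C)cc2C)nn1`: 21500 nM

Both compounds were tested in an ADME assay on MT4 cells (Homo sapiens) for cytotoxicity, read by MTT assay, with a stated time of 5 days; a lower number here means that less compound is tolerated, a higher number that more compound is tolerated. Compound 1 gives 19400 nM there, and compound 2 gives 21500 nM, so the two numbers lie within the scatter of each other and neither compound can be told apart from the other. Going by the values given here, the only change between them, a 1.1-fold higher number from compound 1 to compound 2 (0.04 log units; within the scatter), left the read-out where it was.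

Compound 3, `Cc1cc(C)c(Oc2cc(Nc3ccc(C#N)cc3)ncc2C(=O)NCc2cn(CC(=O)N3CCCC3)nn2)c(C)c1`, is not yet measured. It differs from compound 2 by (pyrrolidin-1-yl)carbonyl in place of (ethoxycarbonyl)methyl on a saturated chain carbon bound to an aromatic nitrogen. Among the compounds with values here, no measured step swaps an ester for an amide, so the only guide is the single step from compound 1 to compound 2, which also altered the group on that chain carbon and stayed within the scatter. On that basis compound 3 is expected to sit close to compound 2 in this assay, with a step of a 1.1-fold lower number from compound 2 to compound 3 (0.03 log units; within the scatter), that is, no change beyond the scatter. The estimate for compound 3 is 20000 nM, with a range from 8000 nM to 50000 nM.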

Compound 3, half-maximal cytotoxic concentration: 58100 nM
For compound 3 the middle estimate is 2.9-fold (0.46 log units) below the measured one; measured number outside the range, above it.
By their numbers in this assay, from the lowest: compounds 1 and 2 (each within the scatter of the next); then compound 3.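

In this assay, the group on the saturated chain carbon bound to an aromatic nitrogen turns out to matter: compounds 1 and 2 could not be told apart, but the pyrrolidine amide brings a 2.7-fold higher number from compound 2 to compound 3 (0.43 log units; beyond the scatter), a modest step beyond the scatter. The second comparison is the cleaner one, since 2-(ethoxycarbonyl)ethyl in compound 2 differs from the chain in the other two compounds, whereas pyrrolidin-1-yl in place of methyl on a carbonyl carbon gives a 3.0-fold higher number from compound 1 to compound 3 (0.48 log units; beyond the scatter), also modest and beyond the scatter, so among these three compounds more is tolerated only with the (pyrrolidin-1-yl)carbonyl group. Nothing measured here accounts for this shift.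

The compounds shown leave open whether the ring itself matters or any amide at this place would do, a question that an open-chain dimethylamide or a piperidine amide could address. They also leave open how a carboxylic acid or a simple amine on the same chain would read in this assay.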